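This account rests on a few compounds, and the source may have more. Where it says the series, first, only, none or still open, it means among the compounds named here.

Series of nitroimidazole dithiocarbamates on a shared core. Compound 1 `Cc1ncc([N+](=O)[O-])n1CC(O)CSC(=S)N1CCN(c2ccccn2)CC1` in a toxicity assay on HeLa cells (Homo sapiens) for cytotoxicity, read by MTT assay, with a stated time of 24 h (a higher number here means a weaker inhibitor, a lower number a stronger inhibitor), gives 2970000 nM. Compound 2 `Cc1ncc([N+](=O)[O-])n1CC(O)CSC(=S)N1CCN(c2ncccn2)CC1` in this assay gives 2040000 nM; the two values sit together, as the step of a 1.5-fold lower number from compound 1 to compound 2 (0.16 log units; within the scatter) shows. Compound 3 `Cc1ncc([N+](=O)[O-])n1CC(O)CSC(=S)N1CCN(c2cccc(Cl)c2)CC1` differs from compound 2 by 3-chlorophenyl in place of pyrimidin-2-yl on an amine nitrogen in a ring. Among the measured compounds shown here, only the one step, from a pyridin-2-yl to a pyrimidin-2-yl, is known on this nitrogen, and it stayed within the scatter; no exchange of a heteroaromatic ring for a chlorophenyl has been measured. No step beyond the scatter in this assay is therefore expected, and the expected step is a 1.1-fold lower number from compound 2 to compound 3 (0.05 log units; within the scatter). Compound 3 is estimated at 1800000 nM, with a range of 700000 nM to 5000000 nM.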

Compound 3, half-maximal inhibitory concentration: 1080000 nM
Compound 3: the middle estimate sits 1.7-fold (0.22 log units) above what was measured; low and high end bracket the measured number.
By their numbers in this assay, from the lowest: compounds 3, 2 and 1 (each within the scatter of the next, the first and the last beyond it).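

Among the compounds shown here, on the amine nitrogen in the ring, the first exchange for a ring of carbon only gives in this assay a 1.9-fold lower number from compound 2 to compound 3 (0.28 log units; within the scatter) and also a 2.8-fold lower number from compound 1 to compound 3 (0.44 log units; beyond the scatter); the latter is the first step at this position beyond the scatter, and it is modest. For the compounds shown here, the position therefore shows a small response across these three aryl groups, and only the pair of compound 1 and compound 3 separates. No measurement given here accounts for that step. As far as these compounds go, whether the chlorine or the carbon-only ring carries the step stays open. A plain phenyl, or a methoxy group or carboxylic acid in place of the chlorine, would separate the two.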